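From methoxy to trifluoromethyl in compound 1

The compounds below may be only part of what the source reports. "The series", "measured", "known", "first", "only" and "open" are said of these compounds alone.

Compound 1 `COc1cc(N2C(=O)C3(CCC3)N(c3ccc(OC4CCN(C)CC4)nc3)C2=S)cnc1C#N` gives 2.93 L/kg
Compound 2 `CN1CCC(Oc2ccc(N3C(=S)N(c4cnc(C#N)c(C(F)(F)F)c4)C(=O)C34CCC4)cc2)CC1` gives 12 L/kg

In an ADME assay on the whole organism (Mus musculus, strain CD1) for pharmacokinetics, at a dose of 2 mg/kg by the intravenous route (a higher number here means that more of the compound sits outside the plasma, a lower number that more of the compound stays in the plasma), compound 1 stands lowest of the two at 2.93 L/kg on this scale, and compound 2 lies higher, beyond the usual scatter, at 12 L/kg on the same scale. Compound 3 `CN1CCC(Oc2ccc(N3C(=S)N(c4cnc(C#N)c(C(F)(F)F)c4)C(=O)C34CCC4)cn2)CC1` has not been measured yet. Its change from compound 1 is trifluoromethyl in place of methoxy on an aromatic carbon in one place: trifluoromethyl in place of methoxy on an aromatic carbon, ortho to a cyano group. Within the data shown here, no measured pair shows this change alone, so the size of the step is uncertain. Compound 2 also carries trifluoromethyl and gives 12 L/kg as its number, which is the only ground for expecting an upward move. The expected step is a 2.4-fold higher number from compound 1 to compound 3 (0.38 log units; beyond the scatter) upward, probably somewhat beyond the scatter. For compound 3 the estimated value is 7 L/kg with an expected range from 3.5 L/kg to 14 L/kg in this assay once measured.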

Compound 3, volume of distribution at steady state: 7.69 L/kg
Beside the measured number, compound 3's estimate is 1.1-fold (0.04 log units) below it; low and high end bracket the measured number.
By their numbers in this assay, from the lowest: compound 1; then compounds 3 and 2 (each within the scatter of the next).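

In this assay, replacing methoxy with trifluoromethyl on the aromatic carbon ortho to a cyano group, with the rest of the molecule unchanged, gives a 2.6-fold higher number from compound 1 to compound 3 (0.42 log units; beyond the scatter). Among these compounds, this is the first reading of this change on its own: compound 1 and compound 2 differ in more than one place, so their gap could not be tied to this position, whereas this modest rise beyond the scatter shows that this one replacement is enough to move the number upward. Nothing measured here bears on why the number rises.

Among the compounds shown here, only two groups have been compared at this position, and only on one core, so it remains open whether the same replacement would give a similar step elsewhere. Also open, from the compounds shown here alone, is where a chlorine atom, a methyl group or an amine at this position would fall in this assay.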